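The source may hold more compounds than are shown below. What is called first, only, known or untested is meant among the compounds shown, and "the series" means these compounds.

The measured compounds:

- compound 1 `Cc1ccc2nc(N3CCCc4ccc(F)cc4C3)cc(NCCN3CCNCC3)c2c1` gives 40000 nM
- compound 2 `Cc1ccc2nc(N3CCCc4ccc(F)cc4C3)cc(NC(=O)CN)c2c1` returns only a limit, > 100000 nM

In an ADME assay on HEp-2 cells (Homo sapiens) for cytotoxicity, read by CCK-8 assay, with a stated time of 5 days (a lower number here means that less compound is tolerated, a higher number that more compound is tolerated), compound 1 gives 40000 nM. As far as these compounds go, for compound 2 the assay reports no number but a limit, > 100000 nM, so compound 2 stands at the limit of > 100000 nM in this assay, at which 1 of the 2 values shown sits, and its true value is unknown beyond that. Going by the values given here, the one measured step, an at least 2.5-fold higher number from compound 1 to compound 2 (0.39 log units; beyond the scatter), moved the number upward when the side chain on the ring nitrogen was exchanged.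

Compound 3 `Cc1ccc2nc(N3CCCc4ccc(F)cc4C3)cc(NC3(CN)COC3)c2c1` differs from compound 2 in the same position: 3-(aminomethyl)oxetan-3-yl in place of (aminomethyl)carbonyl on a nitrogen on an aromatic ring. Among the compounds with values here, no measured pair carries exactly this exchange, so the estimate rests on the single step from compound 1 to compound 2, which shows that the group on this nitrogen can shift the read-out by at least a modest amount. Compound 3, with its primary amine on the oxetane carrying a non-aromatic ring rather than a carbonyl, is expected to sit between the two measured compounds, with a value near 60000 nM (range 25000 nM to 150000 nM), which would mean an expected step of an at least 1.6-fold lower number from compound 2 to compound 3 (0.22 log units; that floor lies within the scatter); the chance that only a limit is returned again is real.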

Compound 3, half-maximal cytotoxic concentration: 86000 nM
Beside the measured number, compound 3's estimate is 1.4-fold (0.16 log units) below it; low and high end bracket the measured number.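

Placing 3-(aminomethyl)oxetan-3-yl on the nitrogen on an aromatic ring in place of 2-(piperazin-1-yl)ethyl also moves the number upward in this assay (a 2.2-fold higher number from compound 1 to compound 3 (0.33 log units; beyond the scatter)). A second group that has no carbonyl and no piperazine therefore departs from compound 1 in the same direction as (aminomethyl)carbonyl, and compound 3 shows this with a measured number rather than a limit. The exchange of the two smaller groups can be read only as a floor that lies within the scatter (an at least 1.1-fold lower number from compound 2 to compound 3 (0.06 log units; that floor lies within the scatter)), and no order between them can be claimed. Compound 2 gives a limit and not a number, which is what reduces that step to a floor: the limit of > 100000 nM in this assay, at which 1 of the 3 values shown sits.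

The compounds shown leave open how much of the tolerance in this assay belongs to the primary amine, which both smaller groups carry, and how much to what holds it on the nitrogen. As far as these compounds go, it also remains open how a hydroxymethyl in place of the aminomethyl on the oxetane, or a longer chain ending in a primary amine on the same nitrogen, would read.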